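The compounds below may be only part of what the source reports. "The series", "measured", "known", "first", "only" and "open" are said of these compounds alone.

Measured compounds:
- compound 1, `CCCCCCn1c(N)nc2ccccc21`: 3960 nM
- compound 2, `NCc1cccc(Cn2c(N)nc3ccccc32)c1`: "not active" (no number reported)
- compound 3, `CCCCCn1c(N)nc2c(C)cccc21`: 1130 nM

All three were tested in an assay on HEK293 cells for agonist activity at Toll-like receptor 8 (Homo sapiens), read by reporter gene assay; on this read-out lower numbers stand for an effect already at smaller amounts and higher numbers for an effect only at larger amounts of compound. Of the two compounds that gave a number, compound 3 stands lowest: compound 1 gives a higher number, and the gap between the two lies beyond the usual scatter of repeated measurements. Compound 2 was reported as not active, with no number attached, so it cannot be placed on the same scale.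

The next compound, compound 4, has the structure `CCCCCn1c(N)nc2c(F)cccc21`. It differs from compound 3 in a single place: fluoro in place of methyl on an aromatic carbon. Both groups are small and sit on the same carbon of the shared core, so the change is a modest one.

For the measured compounds named here, no pair of measured compounds differs in only one place, so there is no measured step to lean on here. Compound 4 is expected to land close to compound 3, with the number drifting slightly higher if anything. Compound 4 is estimated at about 1500 nM, with a likely range from 500 nM to 5000 nM. That estimate corresponds to a step of a 1.3-fold higher number from compound 3 to compound 4 (0.12 log units; within the scatter), which is expected to stay within the usual scatter.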

Compound 4, half-maximal effective concentration: "not active" (no number reported)
No number was reported for compound 4; the estimate stays without a comparison.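

For the compounds shown here, compound 4 was reported as not active, with no number attached, so no step from compound 3 to compound 4 can be read. The compounds shown leave open how large the effect of swapping methyl for fluoro on this aromatic carbon really is. Nothing available offers an explanation for this result.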